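Lengthening the amide nitrogen chain: compound 3 to compound 4

This account rests on a few compounds, and the source may have more. Where it says the series, first, only, none or still open, it means among the compounds named here.

Compound 1 `CCN(C(=O)c1ccccc1OCc1ccccc1)[C@@H]1CC[C@H](N)C1` in an assay on HEK293 cells for inhibition of transient receptor potential cation channel subfamily M member 8 (Homo sapiens), read by FLIPR and calcium flux (a higher number here means a weaker inhibitor, a lower number a stronger inhibitor), gives > 5000 nM, which is a limit of the assay and not a number.
Compound 2 `CCN(C(=O)c1ccccc1OCc1ccccc1)[C@@H]1CC[C@@H](N)C1` gives 2600 nM.
Compound 3 `CCCN(C(=O)c1ccccc1OCc1ccccc1)[C@@H]1CCC[C@H](N)C1` gives 1430 nM.

Of the two numbers seen, compound 3 has the lowest; compound 2 stands nearest, within the scatter. Compound 4 `CCCCN(C(=O)c1ccccc1OCc1ccccc1)[C@@H]1CCC[C@H](N)C1` has not yet been measured. It differs from compound 3 by methyl in place of hydrogen on a saturated chain carbon, three bonds along the chain from an amide-type nitrogen, so the chain on the amide nitrogen goes from propyl to butyl. Among the measured compounds shown here, the only measured step, an at least 1.9-fold lower number from compound 1 to compound 2 (0.28 log units; that floor lies within the scatter), rests on the fact that compounds 1 and 2 differ only in the configuration as drawn and concerns configuration, not chain length, so it offers no guide here. With nothing pointing either way, the expected step is a 1.2-fold lower number from compound 3 to compound 4 (0.08 log units; within the scatter), within the scatter. Compound 4 is estimated at 1200 nM, with a range from 450 nM to 3500 nM.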

Compound 4, antagonist equilibrium constant: 1560 nM
Estimate against measurement, compound 4: 1.3-fold (0.11 log units) below, within the range that was stated.
By their numbers in this assay, from the lowest: compounds 3, 4 and 2 (each within the scatter of the next). At a limit, above all of these: compound 1.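

Among the compounds shown here, compound 3 and compound 4 give the first direct reading of chain length on the amide nitrogen, with the rest of the structure held the same: going from propyl to butyl gives a 1.1-fold higher number from compound 3 to compound 4 (0.04 log units; within the scatter). In this assay the two numbers cannot be told apart, so at this position the added methyl makes no measurable difference. Nothing at hand bears on why this step is so small.

As far as these compounds go, whether a pentyl chain, a branched isopropyl group or a chain ending in a hydroxyl group would give a different number remains open.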